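The source may report more compounds than this note shows. Statements on the series, on what has been measured and on what is new or still open speak of the compounds shown alone.

Measured so far:
compound 1 `C[C@H](NC(=O)CN(c1nc(Cl)nc2[nH]cnc12)C1CC1)C(=O)OCc1ccccc1` — in a functional assay on the whole organism (Tail, strain ICR) with Mus musculus as the target, in the tail flick test, with a stated time of 90 min, at a dose of 25 umol/kg by the oral route (on this read-out lower numbers stand for a weaker effect and higher numbers for a stronger effect at the one dose given), compound 1 gives 44.2%.
compound 2 `N=C(N)NCCC[C@H](NC(=O)CN(c1nc(Cl)nc2[nH]cnc12)C1CC1)C(=O)O` — in this assay compound 2 gives 27.6%.

Compound 1 stands highest of the two numbers in this assay; the nearest is compound 2, whose value lies lower by a gap beyond the usual scatter. Within the data shown here, these two compounds differ in more than one place, so no single step between them is drawn; their values show only that compound 1 gives the stronger read-out of the pair at the dose used.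

Compound 3 `NCCCC[C@H](NC(=O)CN(c1nc(Cl)nc2[nH]cnc12)C1CC1)C(=O)OCc1ccccc1` is not yet measured in this assay. It differs from compound 1 by 3-aminopropyl in place of hydrogen on a saturated chain carbon, two bonds along the chain from an amide-type nitrogen and a carbonyl carbon. Among the measured compounds shown here, no measured pair isolates this change, so an expectation can rest on the value of compound 1 alone. The change is expected to move the read-out in this assay only modestly, if at all, and slightly downwards rather than upwards; the expected step is a number 6.2 percentage points lower from compound 1 to compound 3 (within the scatter), which stays close to the scatter of the method. Compound 3 is therefore estimated at 38%, with a range from 20% to 56%.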

Compound 3, a percentage reported as activity, at one dose (the size of the read-out at that dose, not a potency): 35.3%
Beside the measured number, compound 3's estimate is 2.7 percentage points above it, within the range that was stated.
By their numbers in this assay, from the lowest: compounds 2, 3 and 1 (each within the scatter of the next, the first and the last beyond it).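

In this assay, among these compounds, the one readable step is a number 8.9 percentage points lower from compound 1 to compound 3 (within the scatter). At this saturated chain carbon, two bonds along the chain from an amide-type nitrogen and a carbonyl carbon, 3-aminopropyl in place of hydrogen therefore gives no change that can be told from the scatter; cut one bond further out, the same difference reads methyl to 4-aminobutyl. Among the compounds shown here, this is the first sign from a single-place difference that the position accepts a chain ending in an amine with the read-out held at this one dose and time, though the single step cannot rule out a small loss. No measured property accompanies the step, so the data offer no explanation for the result.

The compounds shown leave open whether a carboxylic acid or a hydroxyl group at the chain end, or a shorter or longer chain at this carbon, would give the same result. They also leave open whether the 3-aminopropyl change would read the same with a free carboxylic acid in place of the ester shared by compound 1 and compound 3.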